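A chloropyridinyl isomer of compound 3

This account rests on a few compounds, and the source may have more. Where it says the series, first, only, none or still open, it means among the compounds named here.

Three amides on a shared core have been measured in an ADME assay on BJ cells (Homo sapiens) for inhibition, with a stated time of 72 h; on this read-out lower numbers stand for an effect already at smaller amounts and higher numbers for an effect only at larger amounts of compound. Compound 1 `C=CC(=O)Nc1cccc(-c2nc3ccccc3s2)c1` gives only the limit > 25000 nM in this assay. Compound 2 `O=C(CCl)Nc1cccc(-c2nc3ccccc3s2)c1` gives 8500 nM in this assay. Compound 3 `O=C(Nc1cccc(-c2nc3ccccc3s2)c1)c1cccnc1Cl` likewise gives only the limit > 25000 nM in this assay, so compound 3 stands at the limit, where two of the three values sit (the limit of > 25000 nM in this assay, at which 2 of the 3 values shown sit). Among the measured steps, an at least 2.9-fold lower number from compound 1 to compound 2 (0.46 log units; beyond the scatter) and an at least 2.9-fold higher number from compound 2 to compound 3 (0.46 log units; beyond the scatter), while there is a step that the two limits leave unreadable from compound 1 to compound 3. Compound 4 `O=C(Nc1cccc(-c2nc3ccccc3s2)c1)c1ccncc1Cl` has not yet been measured; it differs from compound 3 by 3-chloropyridin-4-yl in place of 2-chloropyridin-3-yl on a carbonyl carbon, the two having the same atoms joined differently. Among the compounds with values here, no measured step changes where the chlorine sits within a chloropyridinyl group; the step from compound 2 to compound 3 is the only one that places such a group on the carbonyl carbon, and it ended at the limit. Compound 4 is therefore expected to remain at or close to the limit of this assay, with an expected step of a number no higher from compound 3 to compound 4 (the limit leaves the size open) that would not exceed the scatter. The estimate for compound 4 in this assay is 25000 nM, within 9000 nM to 70000 nM.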

Compound 4, half-maximal effective concentration: > 25000 nM
Compound 4: a limit, no number; the forecaster's own chance of this, stated with the estimate: 75%; the middle value sits exactly at the limit.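

In this assay compound 4 gives > 25000 nM, which is a limit and not a number. Placing 3-chloropyridin-4-yl instead of chloromethyl on a carbonyl carbon gives an at least 2.9-fold higher number from compound 2 to compound 4 (0.46 log units; beyond the scatter), so the rise seen with 2-chloropyridin-3-yl at this place is not confined to that one chloropyridinyl group. The steps from compound 3 to compound 4 and from compound 1 to compound 4 cannot be read, so moving the chlorine and the ring nitrogen leaves no measurable difference between the two isomers, and the values shown gather at one end: the limit of > 25000 nM in this assay, at which 3 of the 4 values shown sit.

Among the four amides, only compound 2 gives a number, 8500 nM, so it remains open how far any group on this carbonyl carbon can shift the read-out. Whether a bromomethyl group, a longer chloroalkyl chain, or a pyridinyl ring without chlorine would give a number in this assay, and how such a number would compare with that of compound 2, stays unanswered.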